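Ring-opened acid analogue of a CDK8 acrylamide

A few compounds are considered here, and "the series" means these few. Any claim that something is new, unique, unknown or untested is made for them only; others in the source may bear on it.

Compound 1, `O=C(O)[C@@H]1CCCN1C(=O)/C=C/c1ccncc1-c1ccc2ccccc2c1`, was examined in an assay on a protein complex for inhibition of CDK8/Cyclin C (Homo sapiens), with a stated time of 1 h, tested at 10 uM (on this read-out higher numbers stand for more inhibition at the one concentration tested (going by the name of the read-out) and lower numbers for less inhibition), and gave 67%. That is the higher of the two numbers recorded, and its nearest neighbour is compound 2, `O=C(O)COc1ccncc1-c1ccc2ccccc2c1`, which in this assay gave 16%, a gap that lies beyond the usual scatter. The two structures differ in more than one place, so their values are simply shown side by side without a single step being drawn between them.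

Compound 3, `O=C(O)CCNC(=O)/C=C/c1ccncc1-c1ccc2ccccc2c1`, has not yet been measured. It differs from compound 1 by (2-carboxyethyl)amino in place of 2-carboxypyrrolidin-1-yl on a carbonyl carbon. Among the measured compounds shown here, no step between measured compounds is available to set a size for this kind of change. Since the double bond outside the aromatic rings and the carboxylic acid are both kept, a moderate decrease is expected rather than a collapse, and the step of a number 22 percentage points lower from compound 1 to compound 3 (beyond the scatter) is estimated to be downward but of uncertain size. Compound 3 is therefore expected to give about 45% in this assay, with a plausible range from 20% to 70%.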

Compound 3, a percentage reported as inhibition, at one concentration (the size of the read-out at that concentration, not a potency): 91%
For compound 3 the middle estimate is 46 percentage points below the measured one; measured number outside the range, above it.
By their numbers in this assay, from the lowest: compound 2; then compound 1; then compound 3.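

In this assay, replacing 2-carboxypyrrolidin-1-yl with (2-carboxyethyl)amino on the carbonyl carbon gives a number 24 percentage points higher from compound 1 to compound 3 (beyond the scatter), so the change raises the inhibition recorded at the one concentration tested. At this place, then, neither the five-membered non-aromatic ring nor the defined stereocentre of compound 1 is needed for this level of inhibition, since compound 3 has neither and still gives the higher number. The change removes the ring and the stereocentre and adds a hydrogen-bond donor all at once, so this single step cannot assign the rise to any one of them, and no supporting data bear on its origin.

The compounds shown leave open whether the carboxylic acid is needed on this open chain, a question that an amine such as (2-aminoethyl)amino on the same carbonyl carbon would address, and whether a longer chain such as (3-carboxypropyl)amino would keep the number reached by compound 3. They also leave open how compound 3 would rank as a potency, as its value comes from a single concentration.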